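Isopropyl for Methyl on Sulfur: Expected Cytotoxicity of Compound 4

This account rests on a few compounds, and the source may have more. Where it says the series, first, only, none or still open, it means among the compounds named here.

Compound 1 `Nc1nc(NC2CC2)c2ncn(/C=C3/CC3(CO)CO)c2n1`, compound 2 `COCCOc1nc(N)nc2c1ncn2/C=C1/CC1(CO)CO` and compound 3 `CSc1nc(N)nc2c1ncn2/C=C1/CC1(CO)CO` share one core and differ only in the group on a single aromatic carbon. In an ADME assay on CCRF-HSB-2 cells (Homo sapiens) for cytotoxicity, with a stated time of 7 days (a lower number here means that less compound is tolerated, a higher number that more compound is tolerated), compound 1 gives only a limit, > 20000 nM. Compound 2 also reaches only a limit, > 20000 nM. Compound 3 likewise stands at a limit, > 100000 nM. Among the three values, compound 3 sits at the limit of > 100000 nM in this assay, at which 1 of the 3 values shown sits, whereas the other two sit at the limit of > 20000 nM in this assay, at which 2 of the 3 values shown sit. The steps a step that the two limits leave unreadable from compound 1 to compound 2, a step that the two limits leave unreadable from compound 1 to compound 3 and a step that the two limits leave unreadable from compound 2 to compound 3 therefore cannot be read in size or direction.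

Compound 4 `CC(C)Sc1nc(N)nc2c1ncn2/C=C1/CC1(CO)CO` differs from compound 3 by isopropyl in place of methyl on a sulfur. Going by the values given here, none of the measured steps touches a methylsulfanyl group, and none could be read, so no step beyond the scatter is expected in this assay in either direction. Compound 4 is therefore expected to give an estimated 100000 nM with a range from 30000 nM to 300000 nM. The expected step is a number no higher from compound 3 to compound 4 (the limit leaves the size open), and the result is expected most likely to be reported again only as a limit.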

Compound 4, half-maximal cytotoxic concentration: 94000 nM
For compound 4 the middle estimate is 1.1-fold (0.03 log units) above the measured one; low and high end bracket the measured number.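

In this assay, going by these compounds alone, compound 4 gives the first number at this position that is not a limit, 94000 nM. Isopropyl in place of methyl on a sulfur comes with an at least 1.0-fold lower number from compound 3 to compound 4 (0.02 log units; that floor lies within the scatter), so the change can be read in one direction only, and what can be read does not separate the two compounds. Compound 3 remains a limit of the assay, and the full size of the step cannot be told from it: the limit of > 100000 nM in this assay, at which 1 of the 4 values shown sits.

Going by these compounds, the steps to compound 4 from compound 1 and from compound 2 cannot be read, and both of those compounds stand at a limit: the limit of > 20000 nM in this assay, at which 2 of the 4 values shown sit. Whether a longer chain on the sulfur, such as n-butyl, or a benzyl group there would end beyond the scatter of compound 4 stays open.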